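A few compounds are considered here, and "the series" means these few. Any claim that something is new, unique, unknown or untested is made for them only; others in the source may bear on it.

Working notes on a series built on the core of compound 1. For the measured compounds named here, in an ADME assay on NHDF cells (Homo sapiens) for cytotoxicity, read by MTT assay, with a stated time of 72 h (a lower number here means a stronger inhibitor, a higher number a weaker inhibitor), compound 1 (`COc1ccc(/C=C2\CCC/C(=C\c3ccccc3Cl)C2=O)cc1OC`) gives 21600 nM and compound 2 (`COc1ccc(/C=C2\CCC/C(=C\c3cc(Cl)cc(Cl)c3)C2=O)cc1OC`) gives 8300 nM, the lower of the two numbers so far. Going by the values given here, the one measured step is a 2.6-fold lower number from compound 1 to compound 2 (0.42 log units; beyond the scatter) and it exchanges 2-chlorophenyl for 3,5-dichlorophenyl, so it bears only loosely on the next change.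

Compound 3 (`COc1ccc(/C=C2\CCC/C(=C\c3ccc(O)c(O)c3)C2=O)cc1OC`) carries 3,4-dihydroxyphenyl in place of 3,5-dichlorophenyl on a double-bonded chain carbon bound to a double-bonded ring carbon. Among the compounds with values here, no measured compound carries 3,4-dihydroxyphenyl, so the data give no firm direction for this change. Within the data shown here, the only guide to size is modest (a 2.6-fold lower number from compound 1 to compound 2 (0.42 log units; beyond the scatter)), so no step beyond the scatter is expected in this assay, with a slight lean toward the higher number of compound 1 at 21600 nM as a tentative expectation. The expected step is a 1.4-fold higher number from compound 2 to compound 3 (0.16 log units; within the scatter) and it carries wide uncertainty. For compound 3 the expected value is 12000 nM (estimated range 4000 nM to 35000 nM).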

Compound 3, half-maximal inhibitory concentration: 25200 nM
Compound 3: middle estimate off by 2.1-fold (0.32 log units), on the low side; low and high end bracket the measured number.
By their numbers in this assay, from the lowest: compound 2; then compounds 1 and 3 (each within the scatter of the next).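

At the double-bonded chain carbon bound to a double-bonded ring carbon, this assay registers a 3.0-fold higher number from compound 2 to compound 3 (0.48 log units; beyond the scatter) when 3,4-dihydroxyphenyl replaces 3,5-dichlorophenyl, so this position responds to an exchange that leaves the heavy-atom count unchanged but brings in hydrogen-bond donors and acceptors. Against 2-chlorophenyl, the same group gives a 1.2-fold higher number from compound 1 to compound 3 (0.07 log units; within the scatter), which lies within the scatter, so 3,4-dihydroxyphenyl and 2-chlorophenyl cannot be told apart here and compound 2 alone stands apart from the other two. Chlorine on the ring does not by itself mark the lower number, as compound 1 carries chlorine and is not separated from compound 3, and nothing in hand bears on why the numbers fall this way.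

Still open, on these data alone, is whether the lower number of compound 2 depends on the kind of substituent or on its arrangement on the ring, a question that 3,4-dichlorophenyl or 3,5-dihydroxyphenyl at this position would address directly. The compounds shown also leave open how this position would respond to an aminophenyl or a carboxyphenyl group.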